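Methoxy to butoxy on compound 2

The source may report more compounds than this note shows. Statements on the series, on what has been measured and on what is new or still open speak of the compounds shown alone.

Compound 1 `O=C1OC(Cc2nc(-c3ccccc3)no2)c2ccccc21`: > 10000 nM, a limit
Compound 2 `COc1ccc(C(O)C2OC(=O)c3c(OC)cc(OC)cc32)cc1`: > 10000 nM, a limit

Both compounds were tested in a functional assay on RAW264.7 cells (Mus musculus) for inhibition, read by Griess assay, with stated times of 1 h and 24 h; a lower number here means a stronger inhibitor, a higher number a weaker inhibitor. There compound 2 gives > 10000 nM, which is a limit and not a number. The whole set so far stands at the limit of > 10000 nM in this assay, at which 2 of the 2 values shown sit.

Compound 3 `CCCCOc1ccc(C(O)C2OC(=O)c3c(OC)cc(OC)cc32)cc1` keeps the core of compound 2 and differs in one place: propyl in place of hydrogen on a saturated chain carbon bound to an oxygen on an aromatic ring. This puts propyl in place of hydrogen on a saturated chain carbon bound to an oxygen on an aromatic ring, turning methoxy to butoxy. Going by the values given here, no measured step shows what such a change does in this assay. The expectation is therefore a small shift towards stronger inhibition, or none beyond the scatter, and a reading at the same limit would be no surprise. The expected change is an at least 1.1-fold lower number from compound 2 to compound 3 (0.04 log units; that floor lies within the scatter). Compound 3 is estimated at 9000 nM, with an expected range from 3000 nM to 20000 nM.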

Compound 3, half-maximal inhibitory concentration: 1800 nM
Estimate against measurement, compound 3: 5.0-fold (0.70 log units) above; measured number below the stated range.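

In this assay, going by these compounds alone, compound 3 gives the first reading in the set that is a number and not a limit, while the others leave this position without a readable value: the limit of > 10000 nM in this assay, at which 2 of the 3 values shown sit. Turning methoxy to butoxy, with propyl in place of hydrogen on a saturated chain carbon bound to an oxygen on an aromatic ring, gives an at least 5.5-fold lower number from compound 2 to compound 3 (0.74 log units; beyond the scatter). Within the data shown here, this shows that a change at this position can move the read-out beyond the scatter, which no earlier pair could show.

A single step does not tell whether the number keeps falling as the chain grows, or how a propoxy group or a longer chain such as hexyloxy would read. The compounds shown also leave open what an amine or a carboxylic acid at the end of this chain would do.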